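Replacing a dimethylphenyl group with a methoxyphenyl group

The source may hold more compounds than are shown below. What is called first, only, known or untested is meant among the compounds shown, and "the series" means these compounds.

For the measured compounds named here, in a functional assay on A498 cells (Homo sapiens) for cytotoxicity (on this read-out lower numbers stand for stronger inhibition of growth and higher numbers for weaker inhibition of growth), compound 2 `CSc1ccc(C2=C(c3ccc(C)c(C)c3)C(=O)N3CCCC3C2)cc1` gives 300 nM, and compound 1 `COc1ccc(C2=C(c3ccc(SC)cc3)CC3CCCN3C2=O)cc1C`, the only other compound measured, gives 400 nM. Putting methyl in place of methoxy on an aromatic carbon produced a 1.3-fold lower number from compound 1 to compound 2 (0.12 log units; within the scatter), so these two values cannot be told apart. Compound 3 `COc1ccc(C2=C(c3ccc(SC)cc3)CC3CCCN3C2=O)cc1` has not yet been measured. It differs from compound 2 as follows: 4-methoxyphenyl in place of 3,4-dimethylphenyl on a double-bonded ring carbon. In words, 4-methoxyphenyl stands in place of 3,4-dimethylphenyl on a double-bonded ring carbon. Going by the values given here, the one measured step that bears on this change also trades methoxy and methyl, and it amounted to a 1.3-fold lower number from compound 1 to compound 2 (0.12 log units; within the scatter). Among the compounds with values here, no measured step isolates a 4-methoxyphenyl group, so the range stays wide. The expected change is therefore a 1.3-fold higher number from compound 2 to compound 3 (0.12 log units; within the scatter), with no shift beyond the scatter anticipated. Compound 3 is estimated at 400 nM, with an expected range of 130 nM to 1200 nM.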

Compound 3, concentration for 50% growth inhibition: 800 nM
Beside the measured number, compound 3's estimate is 2.0-fold (0.30 log units) below it; the measured number falls inside the stated range.
By their numbers in this assay, from the lowest: compounds 2, 1 and 3 (each within the scatter of the next, the first and the last beyond it).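

In this assay, for the compounds shown here, 4-methoxyphenyl in place of 3,4-dimethylphenyl on the double-bonded ring carbon gives a 2.7-fold higher number from compound 2 to compound 3 (0.43 log units; beyond the scatter), the first step in this set to lie beyond the scatter, so the substituents on this aromatic ring can shift the read-out measurably. Hydrogen in place of methyl on the methoxy-bearing ring gives a 2.0-fold higher number from compound 1 to compound 3 (0.30 log units; within the scatter), which stays within the scatter, so removing that methyl alone produces no change that can be distinguished from repeat variation. No measurement here speaks to the cause of the larger step.

The compounds shown leave open how an unsubstituted phenyl ring, a 4-chlorophenyl group, or a phenyl ring carrying an amine or a carboxylic acid would behave at this position. As far as these compounds go, whether the step carries over to other cell lines also remains open.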